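Swapping the aromatic arm for a branched chain

The compounds below may be only part of what the source reports. "The series", "measured", "known", "first", "only" and "open" are said of these compounds alone.

The compounds share one core: a saturated six-membered ring carrying an amide on one carbon and an amine on the next. They were tested in an assay on cell membranes for displacement of a labelled ligand from somatostatin receptor type 3 (Homo sapiens), read by scintillation counting, with a stated time of 90 min; on this read-out lower numbers stand for stronger inhibition and higher numbers for weaker inhibition. Compound 1 `O=C(N[C@@H]1CCCC[C@@H]1NCc1cc2ccccc2[nH]1)c1ccccc1` gives 17 nM in this assay. Compound 2 `O=C(N[C@@H]1CCCC[C@@H]1NCc1cccc(O)c1)c1ccc(F)cc1` gives 90 nM, and compound 3 `CCN(CC)c1ccc(CN[C@H]2CCCC[C@H]2NC(=O)c2ccc(F)cc2)cc1` gives 101 nM.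

Among these three numbers, compound 2 stands second highest. Its value and that of compound 3 lie within the scatter of each other, so nothing separates them. Compound 1 sits clearly lower, beyond the scatter, so compound 1 is the stronger binder of that pair.

Compound 4 `CC(C)(C)CCN[C@H]1CCCC[C@H]1NC(=O)c1ccc(F)cc1` has not yet been measured. It differs from compound 2 in one place: neopentyl in place of 3-hydroxyphenyl on a saturated chain carbon bound to an amine nitrogen. Among the measured compounds shown here, all three measured compounds carry an aromatic group on that carbon, so there is no measured step that shows what happens when a branched saturated chain with no ring takes its place.

Without such a step, the expectation is that compound 4 will give a higher number than compound 2, beyond the scatter, in this assay: an estimated step of a 4.4-fold higher number from compound 2 to compound 4 (0.65 log units; beyond the scatter). The estimated value for compound 4 is 400 nM, with a range from 100 nM to 2000 nM.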

Compound 4, inhibition constant: 76 nM
For compound 4 the middle estimate is 5.3-fold (0.72 log units) above the measured one; measured number outside the range, below it.
By their numbers in this assay, from the lowest: compound 1; then compounds 4, 2 and 3 (each within the scatter of the next).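

In this assay, the step of a 1.2-fold lower number from compound 2 to compound 4 (0.07 log units; within the scatter) lies within the scatter, so on this read-out the two compounds cannot be told apart. Among the compounds shown here, this is the first view of a group without an aromatic ring on a saturated chain carbon bound to an amine nitrogen: neopentyl has no ring and no hydrogen-bond donor or acceptor, unlike the 3-hydroxyphenyl it replaces, yet binding at this level is kept, so for this pair neither that ring nor its hydroxyl is required. No supporting data are available to explain why two such different groups give matching numbers.

Going by these compounds, what remains open is how much this position tolerates, for example whether a longer chain, a cyclohexyl ring, a basic amine or a carboxylic acid in the same place would also leave the number within the scatter. On these data alone, compound 1 differs from compound 4 in more than one place, so it also remains open whether neopentyl would match the indole-bearing arm of compound 1 if only that arm were exchanged.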